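The compounds below may be only part of what the source reports. "The series", "measured", "known", "first", "only" and "open" are said of these compounds alone.

Measured compounds and their values:
compound 1, `O=C(Nc1cccc(-n2cc(-c3ccncc3)c(-c3cc(O)cc(Cl)c3)n2)c1)Nc1ccc(Cl)c(C(F)(F)F)c1`: 93%
compound 2, `O=C(Nc1cccc(-n2cc(-c3ccncc3)c(-c3cc(O)cc(Cl)c3)n2)c1)Nc1ccc(Cl)c(Cl)c1`: 59%

In a functional assay on HCT-15 cells (Homo sapiens) for inhibition, read by sulforhodamine B assay, with a stated time of 48 h, tested at 0.01 uM (on this read-out lower numbers stand for a stronger effect and higher numbers for a weaker effect at the one concentration tested), compound 1 gives 93% and stands as the higher of the two numbers; compound 2 gives 59%. For the measured compounds named here, the one measured step, a number 34 percentage points lower from compound 1 to compound 2 (beyond the scatter), concerns the urea end of the shared core, where chloro replaces trifluoromethyl.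

Compound 3, `COc1cc(Cl)cc(-c2nn(-c3cccc(NC(=O)Nc4ccc(Cl)c(C(F)(F)F)c4)c3)cc2-c2ccncc2)c1`, has not been measured. It differs from compound 1 by methyl in place of hydrogen on an oxygen on an aromatic ring, a hydroxy becoming a methoxy on the 3-chloro-5-hydroxyphenyl group. Going by the values given here, no measured step in this assay touches that oxygen, so the step from compound 1 to compound 2 gives no direct guidance here, and the expectation rests on compound 1 alone with a wide range.

Compound 3 is therefore expected to land near the value of compound 1, at an estimated 85% (range 55% to 105%), a step of a number 8 percentage points lower from compound 1 to compound 3 (within the scatter) that is expected to stay within the scatter.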

Compound 3, a percentage reported as activity, at one concentration (the size of the read-out at that concentration, not a potency): 92%
Compound 3: middle estimate off by 7 percentage points, on the low side; measured number inside the range.
By their numbers in this assay, from the lowest: compound 2; then compounds 3 and 1 (each within the scatter of the next).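

In this assay, the step from hydroxy to methoxy on the 3-chloro-5-hydroxyphenyl group reads a number 1 percentage points lower from compound 1 to compound 3 (within the scatter), the first view of this oxygen, whereas the chloro in place of trifluoromethyl change reads a number 34 percentage points lower from compound 1 to compound 2 (beyond the scatter). At the one concentration tested, methyl in place of hydrogen on this oxygen therefore produces no step beyond the scatter, at least with trifluoromethyl on the other end of the molecule. No evidence is available to explain this result.

On these data alone, what the methoxy would give alongside the chloro of compound 2 remains open, since that compound carries the hydroxy. Also open, as far as these compounds go, is how an ethoxy, an amine or a carboxylic acid would read at this place on the shared core.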